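A Methyl Group on the Shared Core in Rat Cells

The source may hold more compounds than are shown below. What is called first, only, known or untested is meant among the compounds shown, and "the series" means these compounds.

Measured so far, in an ADME assay on L6 cells (Rattus norvegicus) for inhibition, read by fluorescence, with a stated time of 72 h; on this read-out higher numbers stand for weaker inhibition and lower numbers for stronger inhibition:
Compound 1 `O=c1ccc2ccc(Oc3ccc(Cl)cc3O)cc2o1` gives 188000 nM.
Compound 2 `Cc1cc(=O)oc2cc(Oc3ccc(Cl)cc3O)ccc12` gives 85900 nM.
Compound 3 `O=c1oc2ccccc2cc1Oc1ccc(Cl)cc1O` gives 108000 nM.

Compound 2 differs from compound 1 by methyl in place of hydrogen on an aromatic carbon; this made a 2.2-fold lower number from compound 1 to compound 2 (0.34 log units; beyond the scatter). Compound 3 has the same atoms as compound 1 joined differently, but the difference between the two cores is not broken down here. Compound 4 `Cc1c(Oc2ccc(Cl)cc2O)c(=O)oc2ccccc12` is not yet measured in this assay; it differs from compound 3 by methyl in place of hydrogen on an aromatic carbon. This is the same kind of change as from compound 1 to compound 2, though not the same: in compound 4 the methyl is also ortho to a group of 9 heavy atoms. Beside the earlier step, a step of a 2.0-fold lower number from compound 3 to compound 4 (0.29 log units; within the scatter) is expected from compound 3 to compound 4, resting on a 2.2-fold lower number from compound 1 to compound 2 (0.34 log units; beyond the scatter). For compound 4 the estimate is 55000 nM, expected between 25000 nM and 120000 nM.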

Compound 4, half-maximal inhibitory concentration: 51500 nM
Compound 4: the middle estimate sits 1.1-fold (0.03 log units) above what was measured, within the range that was stated.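

In this assay methyl in place of hydrogen on an aromatic carbon gave a 2.1-fold lower number from compound 3 to compound 4 (0.32 log units; beyond the scatter) and so repeated on a second core what had been seen on the core of compound 1. The two steps match in size: the same change on two cores in this assay, a 2.2-fold lower number (0.34 log units; beyond the scatter) from compound 1 to compound 2 and a 2.1-fold lower number (0.32 log units; beyond the scatter) from compound 3 to compound 4, 1.0-fold (0.02 log units) apart, within the scatter of two such steps. This shows that the change carried over between these two cores in this one assay, but it does not show why the number falls or whether the same step would appear on a third core.

The compounds shown carry only hydrogen or methyl at these places, so it stays open whether a longer chain, an amine or a carboxylic acid would lower the number too. From the compounds shown here alone, whether the methyl step holds in any other assay also stays open.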